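The compounds below may be only part of what the source reports. "The series", "measured", "known", "first", "only" and "open" are said of these compounds alone.

Measured compounds:
compound 1, `COc1cc(C)cc(-c2c(-c3ccnc(-c4ccc(C(C)=O)cc4)c3)cnn2CC#N)c1`, 34%
compound 2, `Cc1cc(O)cc(-c2nn(CC#N)cc2-c2ccnc(-c3ccc(N(C)C)cc3)c2)c1`, -29%

In a functional assay on SN12C cells (Homo sapiens) for cytotoxicity, read by sulforhodamine B assay, with a stated time of 48 h, tested at 10 uM (on this read-out lower numbers stand for a stronger effect and higher numbers for a weaker effect at the one concentration tested), compound 1 stands highest of the two numbers; compound 2 lies a long way lower, beyond the scatter. Compound 3, `COc1cc(C)cc(-c2c(-c3ccnc(-c4ccc(N(C)C)cc4)c3)cnn2CC#N)c1`, is built from compound 1 by the change (dimethylamino in place of acetyl on an aromatic carbon). Going by the values given here, no measured pair traces this exact change, so the step can only be expected, not read off. Given how far below compound 1 the value of compound 2 falls, the estimate is that the number for compound 3 drops well beyond the scatter, a step of a number 34 percentage points lower from compound 1 to compound 3 (beyond the scatter). Compound 3 is therefore expected to give 0%, within the range -40% to 40%.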

Compound 3, a percentage reported as activity, at one concentration (the size of the read-out at that concentration, not a potency): 16%
Beside the measured number, compound 3's estimate is 16 percentage points below it, and the stated range covers the measured number.
By their numbers in this assay, from the lowest: compound 2; then compound 3; then compound 1.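

Going by these compounds alone, the swap of 4-acetylphenyl to 4-(dimethylamino)phenyl, with the rest of the core of compound 1 kept, isolates this position for the first time in this assay and gives a number 18 percentage points lower from compound 1 to compound 3 (beyond the scatter). The read-out therefore responds to this one change on the aromatic carbon para to a large group, with a modest step. No measurement at hand gives a reason for the step.

On these data alone, it remains open whether a carboxylic acid or a primary amine on that same carbon would move the number further, and in which direction. As far as these compounds go, whether the step would keep its size with a hydroxy group in place of the methoxy group also remains open.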